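Replacing a fluoropyridyl group with a bicyclic lactam

This account rests on a few compounds, and the source may have more. Where it says the series, first, only, none or still open, it means among the compounds named here.

Compound 2 `Nc1ccc(S(=O)(=O)N2CCN(c3ncc(C(O)(C(F)(F)F)C(F)(F)F)cc3-c3cnccc3F)CC2)cn1` is the lower of the two compounds measured in an ADME assay (liver) for metabolic stability, with Liver microsome (Rattus norvegicus) as the target, using microsomes and NADPH, with a stated time of 30 min, tested at 1 uM (on this read-out lower numbers stand for slow clearance and higher numbers for fast clearance), where compound 2 gives 22 mL.min-1.g-1. Among the measured compounds shown here, its neighbour compound 1 `Cc1csc(-c2cc(C(O)(C(F)(F)F)C(F)(F)F)cnc2N2CCN(S(=O)(=O)c3ccc(N)nc3)CC2)c1` carries a 4-methylthiophen-2-yl group at the same position and in this assay compound 1 gives 399 mL.min-1.g-1; the step of an 18-fold lower number from compound 1 to compound 2 (1.26 log units; beyond the scatter) is the only measured change at this position. The unmeasured compound 3 `Nc1ccc(S(=O)(=O)N2CCN(c3ncc(C(O)(C(F)(F)F)C(F)(F)F)cc3-c3ccc4c(c3)CC(=O)N4)CC2)cn1` differs from compound 2 by a group of 10 heavy atoms (8 carbon, 1 nitrogen, 1 oxygen; one five-membered non-aromatic ring with 1 hetero atom, one six-membered aromatic ring of carbon only) in place of a group of 7 heavy atoms (5 carbon, 1 nitrogen, 1 fluorine; one six-membered aromatic ring with 1 hetero atom), on an aromatic carbon on an aromatic carbon, ortho to a large group and two atoms from the ring nitrogen.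

For the measured compounds named here, only the step from compound 1 to compound 2 bears on this change, and it shows that swapping the group at this position can move the clearance by a large amount. The group entering in compound 3 resembles neither of the two measured groups, so the direction is uncertain; a moderate rise is expected rather than none, giving an estimated step of a 2.7-fold higher number from compound 2 to compound 3 (0.44 log units; beyond the scatter). Compound 3 is therefore estimated at 60 mL.min-1.g-1, with a range from 20 mL.min-1.g-1 to 180 mL.min-1.g-1.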

Compound 3, intrinsic clearance in microsomes: 119 mL.min-1.g-1
For compound 3 the middle estimate is 2.0-fold (0.30 log units) below the measured one; the measured number falls inside the stated range.
By their numbers in this assay, from the lowest: compound 2; then compound 3; then compound 1.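

The third group at this position shows that the low clearance of compound 2 does not carry over to every larger replacement: in this assay, the bicyclic lactam gives a 5.4-fold higher number from compound 2 to compound 3 (0.73 log units; beyond the scatter). The same group still keeps much of the advantage over the 4-methylthiophen-2-yl group, with a 3.4-fold lower number from compound 1 to compound 3 (0.53 log units; beyond the scatter), so the position now has an intermediate point rather than only the two extremes seen before, and the order from the lowest number runs compound 2, compound 3, compound 1. Both steps lie beyond the scatter, yet nothing available here accounts for either of them or ties the rise to any one feature of the lactam.

The three compounds cannot separate the contribution of the fused five-membered ring, its amide hydrogen or its carbonyl from that of the six-membered aromatic ring that carries them. Going by these compounds, it also remains open where simpler groups at this position, such as an unsubstituted phenyl ring or a pyridin-3-yl ring without the fluorine, would fall on this scale, and whether the same order would hold with them on the shared core.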